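Adding a Methoxy Group a Second Time

The compounds below may be only part of what the source reports. "The series", "measured", "known", "first", "only" and "open" are said of these compounds alone.

Of the compounds shown here, three have been measured in a functional assay on the whole organism for inhibition, with Rattus norvegicus as the target, at a dose of 1 mg/kg by the oral route; on this read-out lower numbers stand for a weaker effect and higher numbers for a stronger effect at the one dose given. Compound 1 `COc1ccc(-c2cc(OC)cc(C(=O)Nc3nn[nH]n3)n2)cc1` gives 25%. Compound 2 `COc1cc(C(=O)Nc2nn[nH]n2)nc(-c2ccc(OC)c(OC)c2)c1` gives 18%. Compound 3 `Cc1cc(C(=O)Nc2nn[nH]n2)nc(-c2ccccc2)c1` gives 23%. Compound 4 `COc1cccc(-c2cc(C)cc(C(=O)Nc3nn[nH]n3)n2)c1` has not yet been measured in this assay.

From compound 1 to compound 2 the change is methoxy in place of hydrogen on an aromatic carbon, and the step it made was a number 7 percentage points lower from compound 1 to compound 2 (within the scatter). From compound 3 to compound 4 the change is methoxy in place of hydrogen on an aromatic carbon. These are the same kind of change, not the same: in the first the entering methoxy is ortho to a methoxy group and meta to a large group, in the second it is only meta to a large group. The difference between the cores of compound 1 and compound 3 is not broken down here, and the numbers of compound 1 and compound 3 lie within the scatter of each other.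

Compound 4 is expected to give 20%, most likely between 8% and 34%. The expected step is a number 3 percentage points lower from compound 3 to compound 4 (within the scatter). This rests on compound 3 giving 23% and on the earlier step of a number 7 percentage points lower from compound 1 to compound 2 (within the scatter) staying within the scatter.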

Compound 4, a percentage reported as inhibition, in the whole organism at one dose (the size of the read-out at that dose, not a potency): 25%
For compound 4 the middle estimate is 5 percentage points below the measured one; the measured number falls inside the stated range.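

In this assay, methoxy in place of hydrogen on an aromatic carbon gives a number 2 percentage points higher from compound 3 to compound 4 (within the scatter). Set beside the earlier case, the two steps do not differ by more than the scatter of such measurements allows: the same change on two cores in this assay, a number 7 percentage points lower (within the scatter) from compound 1 to compound 2 and a number 2 percentage points higher (within the scatter) from compound 3 to compound 4, 9 percentage points apart, within the scatter of two such steps. So, across these two cores, nothing separates the effect of this change, but both steps are small enough to be lost in the scatter, which means the data show neither that methoxy has a shared effect on the two cores nor that it has any effect at all, and two pairs with differently placed methoxy groups give no general rule.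

The steps shown involve only methoxy entering in place of hydrogen, so it stays open whether an amine, a carboxylic acid or a longer chain such as butoxy on the same aromatic carbon would give a step beyond the scatter. On these data alone, whether the two cores would still behave alike under a change with a larger step also stays open.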